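A few compounds are considered here, and "the series" means these few. Any claim that something is new, unique, unknown or untested is made for them only; others in the source may bear on it.

In a functional assay on KYSE-450 cells (Homo sapiens) for inhibition, read by CCK-8 assay, with a stated time of 48 h; a higher number here means a weaker inhibitor, a lower number a stronger inhibitor:
Compound 1 `COc1ccc(CN(C(=O)CSC(=S)N2CCc3ccccc32)c2cc(OC)c(OC)c(OC)c2)cc1`: 6940 nM
Compound 2 `COc1cc(N(Cc2ccc(C)cc2)C(=O)CSC(=S)N2CCN(C(=O)OC(C)(C)C)CC2)cc(OC)c1OC`: > 20000 nM
Compound 3 `COc1ccc(CN(C(=O)CSC(=S)N2CCN(C(=O)OC(C)(C)C)CC2)c2cc(OC)c(OC)c(OC)c2)cc1OC`: > 20000 nM

Only compound 1 has a numerical reading. Compound 2, at > 20000 nM, is reported only as a limit. Compound 3, at > 20000 nM, is also reported only as a limit, the one described in the limit of > 20000 nM in this assay, at which 2 of the 3 values shown sit.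

Compound 4 `COc1ccc(CN(C(=O)CSC(=S)N2CCN(C(=O)OC(C)(C)C)CC2)c2cc(OC)c(OC)c(OC)c2)cc1[N+](=O)[O-]` carries nitro in place of methoxy on an aromatic carbon, turning 3,4-dimethoxyphenyl into 4-methoxy-3-nitrophenyl: nitro in place of methoxy on an aromatic carbon. Within the data shown here, the one measured step at this group, a step that the two limits leave unreadable from compound 2 to compound 3, gives no size to build on, so no clear step or direction is expected in this assay. The expected change is a step that the limit leaves unreadable from compound 3 to compound 4. Compound 4 is estimated at 22000 nM, with an expected range of 9000 nM to 45000 nM.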

Compound 4, half-maximal inhibitory concentration: 810 nM
The estimate for compound 4 lay 27-fold (1.43 log units) above the measured number; the measured number lies below the stated range.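

In this assay, this aromatic carbon, ortho to a methoxy group, now shows a readable effect, where the earlier step between two limits could not be read: nitro in place of methoxy gives an at least 24-fold lower number from compound 3 to compound 4 (1.39 log units; beyond the scatter). The 4-methoxy-3-nitrophenyl group in place of 4-methylphenyl gives an at least 24-fold lower number from compound 2 to compound 4 (1.39 log units; beyond the scatter). Both steps start from a limit, so their full size remains unknown: the limit of > 20000 nM in this assay, at which 2 of the 4 values shown sit.

The compounds shown leave open whether an amine or a nitrile on this aromatic carbon would give a similar number. They also leave open whether nitro in place of methoxy would give a similar step on the core of compound 1.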